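Swapping a Carboxylic Acid for a Methylamide on an Indole Scaffold

The source may report more compounds than this note shows. Statements on the series, on what has been measured and on what is new or still open speak of the compounds shown alone.

Measured so far:
- compound 1, `CNC(=O)/C=C/c1ccncc1-c1ccc2cc[nH]c2c1`: 103%
- compound 2, `Cn1ccc2cc(-c3cnccc3/C=C/C(=O)O)ccc21`: 102%
- compound 3, `O=C(O)/C=C/c1ccncc1-c1ccc2cc[nH]c2c1`: 103%

Of the compounds shown here, three have been tested in an assay on a protein complex for inhibition of CDK8/Cyclin C (Homo sapiens), with a stated time of 1 h, tested at 10 uM (on this read-out lower numbers stand for less inhibition and higher numbers for more inhibition at the one concentration tested (going by the name of the read-out)), and all three give readings that sit within the usual scatter of one another, so the inhibition in this assay is level across them on this evidence.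

Compound 3 and compound 1 share one core and differ in a single place: methylamino in place of hydroxy on a carbonyl carbon. Going from one to the other, this assay shows no change at the digits printed from compound 3 to compound 1 (within the scatter).

Compound 2 carries a different core from compound 3; the difference between the two cores is not broken down here. Compound 4, `CNC(=O)/C=C/c1ccncc1-c1ccc2c(ccn2C)c1`, has not yet been measured. It stands to compound 2 exactly as compound 1 stands to compound 3: methylamino in place of hydroxy on a carbonyl carbon. The place of the change reads the same in both pairs. It is the same change made on the second core.

Since the same change left the reading essentially unmoved from compound 3 to compound 1, the step from compound 2 to compound 4 is expected to be no change at the digits printed from compound 2 to compound 4 (within the scatter), which rests on the flat step seen in no change at the digits printed from compound 3 to compound 1 (within the scatter) and on the closeness of compound 2 at 102% to the other two. Compound 4 is therefore estimated to give 102% in this assay, most likely between 92% and 110%.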

Compound 4, a percentage reported as inhibition, at one concentration (the size of the read-out at that concentration, not a potency): 99%
Compound 4: middle estimate off by 3 percentage points, on the high side; low and high end bracket the measured number.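

On the second core, methylamino in place of hydroxy on a carbonyl carbon gives a number 3 percentage points lower from compound 2 to compound 4 (within the scatter) in this assay. Set beside the step on the first core, the change carries from one core to the other with no difference that can be told from the scatter: the same change on two cores in this assay, no change at the digits printed (within the scatter) from compound 3 to compound 1 and a number 3 percentage points lower (within the scatter) from compound 2 to compound 4, 3 percentage points apart, within the scatter of two such steps

What this does not show is that the methylcarbamoyl and carboxy compounds are equal in potency: each reading is a single percentage at one concentration, so compounds that read alike here could still differ in the concentration they need to reach that reading, and two cores say nothing about how the change would behave on a third.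

The compounds shown leave open whether other groups on the same carbonyl carbon, such as dimethylamino or ethylamino, would read the same in this assay, and whether the reading would hold if the whole carboxy group gave way to a nitrile or an amine. They also leave open how these compounds would compare across a range of concentrations, which is the kind of measurement that could show whether the carboxylic acids and the methylamides really match.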